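Working notes: methyl to phenyl step on the shared core

The compounds below may be only part of what the source reports. "The series", "measured", "known", "first", "only" and "open" are said of these compounds alone.

Measured so far:
compound 1, `c1ccc(-c2nc3ccc(-n4cnnc4)cc3o2)cc1`: in a functional assay on the whole organism (strain Kunming) with Mus musculus as the target, in the maximal electroshock model, with a stated time of 0.5 h (a higher number here means that more compound is needed for the effect, a lower number that less compound is needed), compound 1 gives 29.5 mg/kg.
compound 2, `Cc1nncn1-c1ccc2nc(-c3ccccc3)oc2c1`: in this assay compound 2 gives 26.5 mg/kg.

Compound 2 holds the lower of the two numbers shown, with compound 1 nearest; the two are separated only by a 1.1-fold lower number from compound 1 to compound 2 (0.05 log units; within the scatter), which lies within the scatter, so no order between them is claimed.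

Compound 3, `c1ccc(-c2nc3ccc(-n4cnnc4-c4ccccc4)cc3o2)cc1`, is still to be measured in this assay. It differs from compound 2 by phenyl in place of methyl on an aromatic carbon. For the measured compounds named here, the only measured step at this position, a 1.1-fold lower number from compound 1 to compound 2 (0.05 log units; within the scatter), stayed within the scatter. Going by the values given here, no measured compound carries a phenyl at this position, so the expectation rests on that single step alone.

The step expected for compound 3 is therefore a 1.1-fold higher number from compound 2 to compound 3 (0.05 log units; within the scatter), none beyond the scatter. Compound 3 is estimated at 30 mg/kg, with a range from 12 mg/kg to 75 mg/kg kept wide for lack of a comparable measured step.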

Compound 3, dose for half-maximal effect: 65.4 mg/kg
Compound 3: middle estimate off by 2.2-fold (0.34 log units), on the low side; measured number inside the range.
By their numbers in this assay, from the lowest: compounds 2 and 1 (each within the scatter of the next); then compound 3.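

For the compounds shown here, on the aromatic carbon between two ring nitrogen atoms, phenyl is the first group to move the number in this assay beyond the scatter, with a 2.5-fold higher number from compound 2 to compound 3 (0.39 log units; beyond the scatter) and, measured against hydrogen, a 2.2-fold higher number from compound 1 to compound 3 (0.35 log units; beyond the scatter). The position is therefore not indifferent to what it carries: methyl in place of hydrogen stayed within the scatter at a 1.1-fold lower number from compound 1 to compound 2 (0.05 log units; within the scatter), while phenyl means that more compound is needed for the effect, by a modest step. Nothing at hand explains this rise.

The three compounds leave open whether the rise belongs to the aromatic ring itself or would also appear with a saturated ring such as cyclohexyl or a longer chain such as propyl. As far as these compounds go, it is also open how an amine or a carboxylic acid at this position would read in this assay.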